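The source may report more compounds than this note shows. Statements on the series, on what has been measured and on what is new or still open speak of the compounds shown alone.

In an assay on HEK293 cells for displacement of a labelled ligand from NPC1-like intracellular cholesterol transporter 1 (Homo sapiens) (on this read-out lower numbers stand for stronger inhibition and higher numbers for weaker inhibition), three compounds have been measured so far:

compound 1, `CC1CCCN(C(=O)CN2CN(c3ccccc3)C3(CCN(C(=O)c4ccc(C5CCCCC5)cc4)CC3)C2=O)C1`: 3600 nM
compound 2, `CS(=O)(=O)NCCNC(=O)CN1CN(c2ccccc2)C2(CCN(C(=O)c3ccc(C4CCCCC4)cc3)CC2)C1=O`: 2100 nM
compound 3, `COC(=O)CCNC(=O)CN1CN(c2ccccc2)C2(CCN(C(=O)c3ccc(C4CCCCC4)cc3)CC2)C1=O`: 12900 nM

Compound 3 gives the highest number of the three. The steps of a 3.6-fold higher number from compound 1 to compound 3 (0.55 log units; beyond the scatter) and a 6.1-fold higher number from compound 2 to compound 3 (0.79 log units; beyond the scatter) both lie beyond the scatter, so compound 3 is the weakest of the measured set, while compound 1 and compound 2 sit within the scatter of each other, as a 1.7-fold lower number from compound 1 to compound 2 (0.23 log units; within the scatter) shows.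

Compound 4, `CS(=O)(=O)NCCCNC(=O)CN1CN(c2ccccc2)C2(CCN(C(=O)c3ccc(C4CCCCC4)cc3)CC2)C1=O`, differs from compound 3 in one place: (methanesulfonamido)methyl in place of methoxycarbonyl on a saturated chain carbon, two bonds along the chain from an amide-type nitrogen. The measured step that bears most directly on this change is a 6.1-fold higher number from compound 2 to compound 3 (0.79 log units; beyond the scatter), which ran in the opposite direction, swapping the methanesulfonamido group for methoxycarbonyl and raising the number by a modest amount. Compound 4 restores the methanesulfonamido group, now on a chain one carbon longer than that of compound 2. Reversing that measured step therefore suggests a downward move of roughly the same size, bringing compound 4 close to where compound 2 stands. Within the data shown here, the extra chain carbon has no measured precedent here, which widens the range.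

Compound 4 is expected to give about 2500 nM in this assay, within a range from 1200 nM to 6000 nM. This estimate means a step of a 5.2-fold lower number from compound 3 to compound 4 (0.71 log units; beyond the scatter).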

Compound 4, half-maximal inhibitory concentration: 3800 nM
For compound 4 the middle estimate is 1.5-fold (0.18 log units) below the measured one; low and high end bracket the measured number.
By their numbers in this assay, from the lowest: compounds 2, 1 and 4 (each within the scatter of the next); then compound 3.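

In this assay, placing (methanesulfonamido)methyl in place of methoxycarbonyl on a saturated chain carbon, two bonds along the chain from an amide-type nitrogen, gives a 3.4-fold lower number from compound 3 to compound 4 (0.53 log units; beyond the scatter); the gap between the methanesulfonamido and methoxycarbonyl series, so far seen only for the shorter chain of compound 2, therefore also appears with the longer chain of compound 4. The chain length itself makes no readable difference at this position, since (methanesulfonamido)methyl in place of methanesulfonamido gives a 1.8-fold higher number from compound 2 to compound 4 (0.26 log units; within the scatter), and (3-(methanesulfonamido)propyl)amino in place of 3-methylpiperidin-1-yl on the carbonyl carbon likewise gives a 1.1-fold higher number from compound 1 to compound 4 (0.02 log units; within the scatter). Nothing measured here offers an explanation for why the methoxycarbonyl compound stands apart from the other three.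

As far as these compounds go, it remains open whether a carboxylic acid or a primary amine at the end of this chain would stay with compounds 1, 2 and 4 or move towards compound 3. From the compounds shown here alone, it is also open whether a still longer chain carrying methanesulfonamido would remain within the scatter of compound 2, and whether this order would hold on a core other than the shared one.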